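From 4-fluorophenyl to 2-bromophenyl on a sulfonyl sulfur

The compounds below may be only part of what the source reports. "The series", "measured", "known", "first", "only" and "open" are said of these compounds alone.

compound 1 `O=C(O)CC(NS(=O)(=O)c1ccccc1)c1ccccc1`: > 100000 nM
compound 2 `O=C(O)CC(NS(=O)(=O)c1ccc(F)cc1)c1ccccc1`: 88400 nM

Both compounds were tested in a functional assay on MDA-MB-231 cells (Homo sapiens) for antiproliferative activity, read by MTT assay, with a stated time of 24 h; a lower number here means a stronger inhibitor, a higher number a weaker inhibitor. Compound 1 stands at the limit of > 100000 nM in this assay, at which 1 of the 2 values shown sits, which is a limit and not a number. For the measured compounds named here, compound 2, at 88400 nM, holds the only actual number so far, so it cannot yet be ranked against a second measured value.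

The next compound is compound 3 `O=C(O)CC(NS(=O)(=O)c1ccccc1Br)c1ccccc1`. Its difference from compound 2 is this: 2-bromophenyl in place of 4-fluorophenyl on a sulfonyl sulfur. Thus 2-bromophenyl stands in place of 4-fluorophenyl on a sulfonyl sulfur.

Going by the values given here, only one measured step bears on this change, and it placed fluoro in place of hydrogen on an aromatic carbon: an at least 1.1-fold lower number from compound 1 to compound 2 (0.05 log units; that floor lies within the scatter). Its floor lies within the scatter, so it offers no firm size for a change of this kind. Among the compounds with values here, the set holds no measured compound with a 2-bromophenyl group. No step beyond the scatter is therefore expected in this assay, and no direction is favoured. The expected step is a 1.1-fold lower number from compound 2 to compound 3 (0.04 log units; within the scatter). For compound 3 the estimated value is 80000 nM, with an expected range of 40000 nM to 160000 nM.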

Compound 3, half-maximal inhibitory concentration: > 100000 nM
Compound 3 gave a limit, no number; the forecaster's own chance of this, stated with the estimate: 35%; middle value at least 1.2-fold (0.09 log units) from the limit.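

In this assay compound 3 gives a limit and not a number, and compound 1 also gives a limit: the limit of > 100000 nM in this assay, at which 2 of the 3 values shown sit. The exchange of 4-fluorophenyl for 2-bromophenyl on a sulfonyl sulfur comes out as an at least 1.1-fold higher number from compound 2 to compound 3 (0.05 log units; that floor lies within the scatter), so this change shows no firm effect on the read-out, in either direction. A halogen on this phenyl ring therefore does not by itself bring a number into this assay, compound 2 remains the only compound shown with an actual value, and the step between compound 1 and compound 3 cannot be read, as both ends of it are limits.

The change from 4-fluorophenyl to 2-bromophenyl alters the halogen and its place on the ring together, and the compounds shown do not separate the two. It also stays open whether a different group on this ring, such as a methoxy group or an amine, would move the number in this assay by more than the scatter, given that all three compounds shown lie close to or at the limit.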